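A few compounds are considered here, and "the series" means these few. Any claim that something is new, unique, unknown or untested is made for them only; others in the source may bear on it.

Of the compounds shown here, three have so far been measured in an assay on isolated protein for inhibition of interferon-induced, double-stranded RNA-activated protein kinase (Homo sapiens), read by luminescence, with a stated time of 10 min; a higher number here means a weaker inhibitor, a lower number a stronger inhibitor. Compound 1 `Oc1nncc(Nc2ccc3cn[nH]c3c2)n1` gives 13000 nM in this assay, and compound 2 `NCc1ccc(C(=O)N/N=C2\C(=O)Nc3ccc(Br)cc32)cc1` gives 12000 nM. Compound 3 `COCCCNc1nccc(-c2c(C)[nH]c3ccccc23)n1` gives 1500 nM, the lowest of the three numbers; its gap to compound 2 and its gap to compound 1 each lie beyond the scatter, so compound 3 is the strongest inhibitor of the three. Compound 4 `Cc1[nH]c2ccccc2c1-c1ccnc(Nc2ccc(F)c(F)c2)n1` has not yet been measured. It differs from compound 3 in one place: 3,4-difluorophenyl in place of 3-methoxypropyl on a nitrogen on an aromatic ring. Going by the values given here, no two measured compounds differ in just this place, so there is no measured step to lean on, and the estimate rests on compound 3 alone. The change is expected to move the number by a small to moderate amount rather than leave it within the scatter, and the expected direction is downward, toward stronger inhibition. The expected step from compound 3 to compound 4 is a 2.5-fold lower number from compound 3 to compound 4 (0.40 log units; beyond the scatter). Compound 4 is therefore estimated at 600 nM, within a range from 150 nM to 3000 nM.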

Compound 4, half-maximal inhibitory concentration: 1500 nM
Compound 4: middle estimate off by 2.5-fold (0.40 log units), on the low side; the measured number falls inside the stated range.
By their numbers in this assay, from the lowest: compounds 3 and 4 (each within the scatter of the next); then compounds 2 and 1 (each within the scatter of the next).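

In this assay, replacing 3-methoxypropyl with 3,4-difluorophenyl on a nitrogen on an aromatic ring gives no change at the digits printed from compound 3 to compound 4 (within the scatter) on the shared core. This position therefore accepts both an open chain holding one hydrogen-bond acceptor and a larger aromatic ring of carbon holding none, with no measurable cost or gain in inhibition for this pair. Nothing at hand explains why two such different groups read alike.

From the compounds shown here alone, with only these two groups compared at this position, it remains open whether a chain ending in an amine or a carboxylic acid would read the same. A plain phenyl ring would show whether the two fluorines count for anything, and a longer chain would test how far the position's acceptance of different groups extends.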